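Series notes: amide-chain variation at the shared core

This account rests on a few compounds, and the source may have more. Where it says the series, first, only, none or still open, it means among the compounds named here.

Measured so far:
- compound 1 `COC1CCN(CC(=O)N2CCN(c3sc(C(F)(F)F)nc3-c3nc4ccccc4[nH]3)C[C@H]2C)C1`: 3380 nM
- compound 2 `C[C@@H]1CN(c2sc(C(F)(F)F)nc2-c2nc3cc(Cl)ccc3[nH]2)CCN1C(=O)Cn1cnc2cccnc21`: 38.5 nM

In a functional assay on Venous blood for antagonist activity at C-X-C chemokine receptor type 3 (Homo sapiens), read by flow cytometry, with a stated time of 30 min, in the presence of a further agent that is not named here (on this read-out lower numbers stand for stronger inhibition and higher numbers for weaker inhibition), compound 1 gives 3380 nM, the highest number of the two. Compound 2 differs from compound 1 in two places and so gives no single-point comparison. In this assay compound 2 gives 38.5 nM, a gap well beyond the scatter.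

Compound 3 `C[C@@H]1CN(c2sc(C(F)(F)F)nc2-c2nc3ccccc3[nH]2)CCN1C(=O)Cn1cc(Cl)cn1` is not yet measured. It differs from compound 1 by 4-chloro-1H-pyrazol-1-yl in place of 3-methoxypyrrolidin-1-yl on a saturated chain carbon bound to a carbonyl carbon. Compound 2 carries an aromatic heterocycle on the same saturated chain carbon, and with its number at 38.5 nM the expectation for compound 3 is a step downward, beyond the scatter, though smaller than the whole gap seen to compound 2, which also differs from compound 1 in a second place. The step from compound 1 to compound 3 is estimated as an 8.5-fold lower number from compound 1 to compound 3 (0.93 log units; beyond the scatter). Compound 3 is expected to give 400 nM, within 80 nM to 2000 nM.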

Compound 3, half-maximal inhibitory concentration: 251 nM
Compound 3: the middle estimate sits 1.6-fold (0.20 log units) above what was measured, within the range that was stated.
By their numbers in this assay, from the lowest: compound 2; then compound 3; then compound 1.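

In this assay, for the compounds shown here, 4-chloro-1H-pyrazol-1-yl in place of 3-methoxypyrrolidin-1-yl on a saturated chain carbon bound to a carbonyl carbon gives a 13-fold lower number from compound 1 to compound 3 (1.13 log units; beyond the scatter), the first reading of a change in one place. This position therefore responds strongly to the group it carries, even though the two groups match in hydrogen-bond donors and acceptors and neither carries a net charge, so those counts do not separate them. No measurement at hand bears on what lies behind the step.

On these data alone, the change swaps the ring and brings in the chlorine at once, so the share of each stays open; an unsubstituted 1H-pyrazol-1-yl on the same chain carbon would bear on that. Compound 2 gives no single-place comparison with either compound.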